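Benzoyl in place of phenylcarbamoyl on the shared core

This account rests on a few compounds, and the source may have more. Where it says the series, first, only, none or still open, it means among the compounds named here.

compound 1 `COc1ccc(S(=O)(=O)Oc2ccccc2NC(=O)Nc2ccccc2)cc1`: > 10000 nM
compound 2 `COc1ccc(S(=O)(=O)Oc2ccccc2NC(=O)c2ccc(F)cc2)cc1`: 550 nM
compound 3 `COc1ccc(S(=O)(=O)Oc2ccccc2NC(=O)Oc2ccccc2)cc1`: > 10000 nM

In a functional assay on NCI-H460 cells (Homo sapiens) for antiproliferative activity (on this read-out lower numbers stand for stronger inhibition and higher numbers for weaker inhibition), compound 1 gives only a limit and no number. Compound 1 thus stands at the limit of > 10000 nM in this assay, at which 2 of the 3 values shown sit, so its position among the three can only be bounded from one side. Compound 4 `COc1ccc(S(=O)(=O)Oc2ccccc2NC(=O)c2ccccc2)cc1` differs from compound 1 by phenyl in place of anilino on a carbonyl carbon. The closest measured step is an at least 18-fold lower number from compound 1 to compound 2 (1.25 log units; beyond the scatter), where a 4-fluorophenyl rather than a phenyl took the place of the anilino; the reverse direction appears as an at least 18-fold higher number from compound 2 to compound 3 (1.25 log units; beyond the scatter). Because an at least 18-fold lower number from compound 1 to compound 2 (1.25 log units; beyond the scatter) was large and the present change is of the same kind, compound 4 is expected to show an at least 12-fold lower number from compound 1 to compound 4 (1.09 log units; beyond the scatter), a strong lowering. Compound 4 is estimated at 800 nM, within 250 nM to 3000 nM.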

Compound 4, half-maximal inhibitory concentration: 410 nM
Estimate against measurement, compound 4: 2.0-fold (0.29 log units) above; the range from low to high includes it.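

In this assay, phenyl on the carbonyl carbon gives an at least 24-fold lower number from compound 1 to compound 4 (1.38 log units; beyond the scatter) and an at least 24-fold lower number from compound 3 to compound 4 (1.38 log units; beyond the scatter), so this position tolerates a plain phenyl and the fluoro is not needed for the gain over anilino and phenoxy. Hydrogen in place of fluoro on an aromatic carbon gives a 1.3-fold lower number from compound 2 to compound 4 (0.13 log units; within the scatter). Compound 1 and compound 3 each give only a limit, not a number: the limit of > 10000 nM in this assay, at which 2 of the 4 values shown sit.

From the compounds shown here alone, how far compound 1 and compound 3 lie beyond that limit stays open. So does whether a nitrile in place of the fluoro, or a benzyl on the carbonyl carbon, would keep the activity of compound 4.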